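This account rests on a few compounds, and the source may have more. Where it says the series, first, only, none or still open, it means among the compounds named here.

Measured so far:
- compound 1 `Cc1cc(N2CC[C@@H](C)[C@@H](N(C)c3ncnc4[nH]ccc34)C2)n2nc(SCCc3ccccc3)nc2n1`: 28000 nM
- compound 2 `CCCSc1nc2nc(C)cc(N3CC[C@@H](C)[C@@H](N(C)c4ncnc5[nH]ccc45)C3)n2n1`: 51200 nM

Both numbers come from a functional assay on BGC-823 cells (Homo sapiens) for inhibition, read by MTT assay, with a stated time of 72 h; a higher number here means a weaker inhibitor, a lower number a stronger inhibitor. Compound 2 at 51200 nM lies within the scatter of compound 1, so these two values give the series no resolved order yet.

Next is compound 3 `Cc1cc(N2CC[C@@H](C)[C@@H](N(C)c3ncnc4[nH]ccc34)C2)n2nc(SCCCc3ccccc3)nc2n1`, which differs from compound 2 by phenyl in place of hydrogen on a saturated chain carbon, three bonds along the chain from a sulfur. In words, this is phenyl in place of hydrogen on a saturated chain carbon, three bonds along the chain from a sulfur. The same difference also reads propyl to 3-phenylpropyl.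

Among the compounds with values here, one measured step bears on this change: a 1.8-fold higher number from compound 1 to compound 2 (0.26 log units; within the scatter). That step also exchanges a phenyl on the chain from the sulfur, there for methyl, and it stays within the scatter. Within the data shown here, a single step is thin evidence, and no measured compound carries the longer chain. In this assay, no shift beyond the scatter is therefore expected, only a slight lean towards the number of compound 1 at 28000 nM. The expected step is a 1.6-fold lower number from compound 2 to compound 3 (0.20 log units; within the scatter). For compound 3 the estimated value is 32000 nM, with an expected range of 13000 nM to 75000 nM.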

Compound 3, half-maximal inhibitory concentration: > 100000 nM
Compound 3: a limit, no number; the forecaster's own chance of this, stated with the estimate: 10%; middle value at least 3.1-fold (0.49 log units) away from the limit.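

In this assay compound 3 gives > 100000 nM, which is a limit of the assay and not a number: the limit of > 100000 nM in this assay, at which 1 of the 3 values shown sits.

Within the data shown here, the longer phenyl-bearing chain on the sulfur gives an at least 3.5-fold higher number from compound 1 to compound 3 (0.55 log units; beyond the scatter), the first step beyond the scatter, and it shows that this position does respond to a change in the chain, which the earlier pair of compounds did not show. Phenyl in place of hydrogen, three bonds along the chain from a sulfur, gives an at least 1.9-fold higher number from compound 2 to compound 3 (0.29 log units; that floor lies within the scatter), and as that floor lies within the scatter, the propyl to 3-phenylpropyl change is bounded only from below and has no resolved size.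

As far as these compounds go, how far compound 3 lies past its limit stays open, and with it the true size of both steps. Also open, from the compounds shown here alone, is how the chain on the sulfur reads with an amine or a carboxylic acid in place of phenyl, or with a still longer chain carrying phenyl.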